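A Ring Nitrogen Restored on the Shared Core

This account rests on a few compounds, and the source may have more. Where it says the series, first, only, none or still open, it means among the compounds named here.

In a functional assay on RKO cells (Homo sapiens) for antiproliferative activity, read by MTT assay, with a stated time of 5 days (on this read-out lower numbers stand for stronger inhibition and higher numbers for weaker inhibition), compound 2 `COc1cc[nH]c1/C=C1\C(=O)Nc2ccc([N+](=O)[O-])c(N[C@H]3CC[C@H](O)CC3)c21` gives 8040 nM, one of only two plain numbers shown; compound 3 `COc1cc[nH]c1/C=C1\C(=O)Nc2ccc(F)cc21` gives 11900 nM, which lies within the scatter of that figure. Compound 1 `COc1cc[nH]c1/C=C1\C(=O)Nc2ccc([N+](=O)[O-])c(N3CCC(O)CC3)c21` reaches only a limit of this assay, < 10 nM. Among the compounds with values here, the single measured step is an at least 800-fold higher number from compound 1 to compound 2 (2.90 log units; beyond the scatter), its true size bounded by the limit of < 10 nM in this assay, at which 1 of the 3 values shown sits. Compound 4 `COc1cc[nH]c1/C=C1\C(=O)Nc2ccc([N+](=O)[O-])c(N3CCCC(CO)C3)c21` differs from compound 2 by 3-(hydroxymethyl)piperidin-1-yl in place of (4-hydroxycyclohexyl)amino on an aromatic carbon, so a piperidin-1-yl group again stands on the aromatic carbon ortho to a nitro group, as in compound 1. That step is the one that bears here, and it points to a large fall in the number, expected as a 200-fold lower number from compound 2 to compound 4 (2.30 log units; beyond the scatter). Compound 4 is therefore estimated at 40 nM, between 6 nM and 400 nM.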

Compound 4, half-maximal inhibitory concentration: 124 nM
The estimate for compound 4 lay 3.1-fold (0.49 log units) below the measured number; the measured number falls inside the stated range.
By their numbers in this assay, from the lowest: compound 4; then compounds 2 and 3 (each within the scatter of the next). At a limit, below all of these: compound 1.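

In this assay, 3-(hydroxymethyl)piperidin-1-yl in place of (4-hydroxycyclohexyl)amino, with the same atoms joined differently, gives a 65-fold lower number from compound 2 to compound 4 (1.81 log units; beyond the scatter), so the large fall at this aromatic carbon is not confined to the 4-hydroxypiperidin-1-yl group. The two piperidin-1-yl groups are still not interchangeable: 3-(hydroxymethyl)piperidin-1-yl in place of 4-hydroxypiperidin-1-yl gives an at least 12-fold higher number from compound 1 to compound 4 (1.09 log units; beyond the scatter). The true size of that step stays bounded by a limit: the limit of < 10 nM in this assay, at which 1 of the 4 values shown sits.

The compounds shown leave open what an unsubstituted piperidine, a morpholine or a piperazine would give on this aromatic carbon, and whether the hydroxyl is needed at all.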